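The source may report more compounds than this note shows. Statements on the series, on what has been measured and on what is new or still open speak of the compounds shown alone.

Measured compounds:
Compound 1 `COc1cc(C)cc(-c2c(-c3ccnc(-c4ccc(C(C)=O)cc4)c3)cnn2CC#N)c1` gives > 100000 nM in a functional assay on NCI-H322M cells (Homo sapiens) for inhibition, read by sulforhodamine B assay, with a stated time of 48 h (a higher number here means a weaker inhibitor of growth, a lower number a stronger inhibitor of growth), which is a limit of the assay and not a number.
Compound 2 `COc1cc(C)cc(-c2nn(CC#N)cc2-c2ccc(-c3cccc(C(C)=O)c3)nc2)c1` gives 4360 nM in this assay.
Compound 3 `Cc1cc(O)cc(-c2nn(CC#N)cc2-c2ccnc(-c3ccc(Oc4ccccc4)cc3)c2)c1` gives 5680 nM in this assay.

Among the two compounds with a number, compound 3 and compound 2 sit within the scatter of each other, so neither can be ranked above the other. Compound 4 `Cc1cc(O)cc(-c2nn(CC#N)cc2-c2ccnc(-c3ccc(N(C)C)cc3)c2)c1` differs from compound 3 by dimethylamino in place of phenoxy on an aromatic carbon. Among the measured compounds shown here, no measured pair shows the effect of this exchange, so nothing in the data fixes its direction. The expectation for the step from compound 3 to compound 4 is a 1.1-fold lower number from compound 3 to compound 4 (0.06 log units; within the scatter), that is, nothing clearly beyond the scatter. Compound 4 is therefore estimated at 5000 nM, with a likely range from 1500 nM to 25000 nM.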

Compound 4, concentration for 50% growth inhibition: 6080 nM
Compound 4: the middle estimate sits 1.2-fold (0.08 log units) below what was measured; low and high end bracket the measured number.
By their numbers in this assay, from the lowest: compounds 2, 3 and 4 (each within the scatter of the next). At a limit, above all of these: compound 1.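

Dimethylamino in place of phenoxy gives a 1.1-fold higher number from compound 3 to compound 4 (0.03 log units; within the scatter) in this assay and thus provides the first reading of a change at this aromatic carbon, para to a large group. Here, a group with no ring and fewer heavy atoms takes the place of phenoxy, with no step beyond the scatter. The compounds shown offer no account of why this step is so small.

On these data alone, whether a primary amine, a carboxylic acid or a longer chain at this carbon would also stay within the scatter remains open. As far as these compounds go, whether the same exchange behaves alike on another core also remains open.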